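The source may hold more compounds than are shown below. What is called first, only, known or untested is meant among the compounds shown, and "the series" means these compounds.

Working notes on the series.

Compound 1 `CC(=O)Nc1cc(-c2cnc(N(C)C(=O)c3c(F)cccc3Cl)c(N3CC4CC4C3)c2)n(C(C)C)n1` stands highest of the three measured compounds in an ADME assay on a cell-free system (plasma, Homo sapiens) (on this read-out lower numbers stand for a smaller free fraction and higher numbers for a larger free fraction), at 0.056. Compound 2 `CC(=O)Nc1cc(-c2ccc(N(C)C(=O)c3c(F)cccc3Cl)c(N3CCCCC3)c2)n(C(C)C)n1` gives 0.004 in this assay, and compound 3 `CC(=O)Nc1cc(-c2ccc(N(C)C(=O)c3c(F)cccc3Cl)c(N3CC4CC4C3)c2)n(C2CCC2)n1` gives 0.003; both sit well apart from compound 1, beyond the scatter. Among the measured compounds shown here, no two measured compounds differ in only one place, so no single-point step can be read from the numbers.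

Compound 4 `CC(=O)Nc1cc(-c2cnc(N(C)C(=O)c3c(F)cccc3Cl)c(N3CCCCC3)c2)n(C(C)C)n1` has not yet been measured in this assay. It differs from compound 1 by a group of 6 heavy atoms (5 carbon, 1 nitrogen; one six-membered non-aromatic ring with 1 hetero atom) in place of a group of 6 heavy atoms (5 carbon, 1 nitrogen; one three-membered non-aromatic ring of carbon only, one five-membered non-aromatic ring with 1 hetero atom), on an aromatic carbon. Given that compound 2 and compound 3 carry other differences as well, the step from compound 1 to compound 4 in this assay is expected to be small, a 1.4-fold lower number from compound 1 to compound 4 (0.15 log units; within the scatter), if anything slightly downward. Compound 4 is estimated at 0.04, within 0.015 to 0.09.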

Compound 4, unbound fraction in the plasma assay: 0.076
Compound 4: the middle estimate sits 1.9-fold (0.28 log units) below what was measured; the measured number falls inside the stated range.
By their numbers in the plasma assay, from the lowest: compounds 3 and 2 (each within the scatter of the next); then compounds 1 and 4 (each within the scatter of the next).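

In the plasma assay, piperidin-1-yl on this aromatic carbon, in place of the group carried by compound 1, gives a 1.4-fold higher number from compound 1 to compound 4 (0.13 log units; within the scatter), so the two ring groups are not separated at this position, with compound 1 at 0.056 and compound 4 at 0.076. In a physicochemical assay for solubility, measured as kinetic solubility (a lower number here means a less soluble compound, a higher number a more soluble compound), the same exchange gives a 1.3-fold lower number from compound 1 to compound 4 (0.11 log units; within the scatter), so this read-out does not separate them either, with compound 1 at 48 ug/mL and compound 4 at 37.4 ug/mL. No measurement at hand offers an explanation for either result.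

Going by these compounds, how morpholin-4-yl or a dimethylamino group would read at this position remains open. So does the effect of any open-chain amine there.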